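The compounds below may be only part of what the source reports. "The series", "measured", "known", "first", "only" and "open" are said of these compounds alone.

Measured so far:
compound 1 `CC(C)C/N=c1\c(O)c(O)\c1=N/Cc1ccc(C#N)cc1`: 10200 nM
compound 2 `CC(/N=c1\c(O)c(O)\c1=N/Cc1ccc(C#N)cc1Cl)C(C)(C)C`: 180 nM

In a functional assay for inhibition, with Rattus norvegicus as the target (a lower number here means a stronger inhibitor, a higher number a weaker inhibitor), compound 1 gives 10200 nM, the highest of the two numbers. Compound 2 gives 180 nM, a lower number, and the gap between the two lies beyond the scatter. Among the compounds with values here, compound 2 differs from compound 1 at more than one place, so the two values show no single step that can be read off.

Compound 3 `CCC(CC)/N=c1\c(O)c(O)\c1=N/Cc1ccc(C#N)cc1` has not yet been measured. It differs from compound 1 in one place: pentan-3-yl in place of isobutyl on a double-bonded nitrogen. Within the data shown here, no step of this kind has been measured among the compounds at hand, so its size in this assay is open; compound 2, which also carries a different alkyl group on the double-bonded nitrogen, gives 180 nM. A moderate step toward a lower number is expected, a 4.1-fold lower number from compound 1 to compound 3 (0.61 log units; beyond the scatter). Compound 3 is estimated at 2500 nM, with a range from 500 nM to 10000 nM.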

Compound 3, half-maximal inhibitory concentration: 1300 nM
For compound 3 the middle estimate is 1.9-fold (0.28 log units) above the measured one; low and high end bracket the measured number.
By their numbers in this assay, from the lowest: compound 2; then compound 3; then compound 1.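

In this assay, within the data shown here, this is the first step that can be read at this position: pentan-3-yl in place of isobutyl on a double-bonded nitrogen gives a 7.8-fold lower number from compound 1 to compound 3 (0.89 log units; beyond the scatter) and so lies beyond the scatter. The change is confined to a carbon group, from 4 heavy atoms to 5, with no ring, hydrogen-bond donor, hydrogen-bond acceptor or net charge on either side, so an exchange between two such alkyl groups is enough to move the number. The data at hand offer no measured reason for this step.

Among these compounds, compound 2 differs from compound 1 and from compound 3 in more than one place, so no step to it can be read. As far as these compounds go, it remains open whether a longer chain, a cyclohexyl ring or a carboxylic acid on that nitrogen would lower the number further or raise it.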